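Swapping a fluorinated ring for pyrimidine in a stability series

The source may report more compounds than this note shows. Statements on the series, on what has been measured and on what is new or still open speak of the compounds shown alone.

compound 1 `CC(Sc1nc2c(cnn2C)c(=O)n1-c1ccccc1)c1ccccn1`: 0.833 h
compound 2 `CC(Sc1nc2c(cnn2C)c(=O)n1-c1ccccc1)c1cccc(F)c1`: 0.133 h

Both numbers come from an ADME assay on microsomes from liver (Mus musculus, strain CD-1) for metabolic stability, read by LC-MS, with a stated time of 60 min, tested at 20 uM; on this read-out lower numbers stand for a shorter-lived compound and higher numbers for a longer-lived compound. Within the data shown here, compound 2 holds the lower of the two, and the only measured step is a 6.3-fold lower number from compound 1 to compound 2 (0.80 log units; beyond the scatter). That step lies beyond the usual scatter, so the group at this place can matter in this assay.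

The next compound, compound 3 `CC(Sc1nc2c(cnn2C)c(=O)n1-c1ccccc1)c1cncnc1`, has not been measured. It differs from compound 2 in one place: pyrimidin-5-yl in place of 3-fluorophenyl on a saturated chain carbon bound to a saturated chain carbon and a sulfur. In words, this is pyrimidin-5-yl in place of 3-fluorophenyl on a saturated chain carbon bound to a saturated chain carbon and a sulfur.

The measured step bears on this change in reverse, since a ring of carbon only leaves and a nitrogen-bearing ring returns, as in compound 1 with 0.833 h. Pyrimidin-5-yl is not pyridin-2-yl, however, and one step is thin evidence. The expected move is therefore upward and of similar size, namely a 5.3-fold higher number from compound 2 to compound 3 (0.72 log units; beyond the scatter). For compound 3 the estimated half-life is 0.7 h, with an expected range of 0.25 h to 2 h.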

Compound 3, half-life: 0.133 h
Beside the measured number, compound 3's estimate is 5.3-fold (0.72 log units) above it, and the stated range ends above it.
By their numbers in this assay, from the lowest: compounds 2 and 3 (each within the scatter of the next); then compound 1.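

In this assay, the change from 3-fluorophenyl to pyrimidin-5-yl gives no change at the digits printed from compound 2 to compound 3 (within the scatter), even though the entering ring carries 2 hydrogen-bond acceptors and the leaving ring carries 0. Replacing pyridin-2-yl with pyrimidin-5-yl at the same place gives a 6.3-fold lower number from compound 1 to compound 3 (0.80 log units; beyond the scatter), so a nitrogen-bearing ring here does not by itself bring the higher number of compound 1, and among these three compounds only the pyridin-2-yl group stands apart. No measurement at hand explains why compound 1 differs from compound 2 and compound 3.

The compounds shown leave open whether the higher number depends on the particular ring of compound 1 or on where its nitrogen sits, which pyridin-3-yl and pyridin-4-yl at this place could help to separate. They also leave open where an unsubstituted phenyl ring would fall, and so whether the 3-fluorophenyl group of compound 2 differs from the plain carbon ring.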